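The compounds below may be only part of what the source reports. "The series", "measured", "known", "first", "only" and "open" are said of these compounds alone.

Compound 2 `O=C(NC1CC[S+]([O-])CC1)N1CCC(c2nc(-c3ccc4ccccc4n3)no2)CC1` is the compound from which this step sets out. Among the measured compounds shown here, in a functional assay on Shh Light II cells (Mus musculus) for inhibition, read by a luciferase reporter (a higher number here means a weaker inhibitor, a lower number a stronger inhibitor), compound 2 gives 850 nM, the higher of the two numbers measured so far, with compound 1 `O=C(Nc1ccccc1C(F)(F)F)N1CCC(c2nc(-c3ccc4ccccc4n3)no2)CC1` nearest to it: in this assay compound 1 gives 700 nM, and the step of a 1.2-fold higher number from compound 1 to compound 2 (0.08 log units; within the scatter) lies within the scatter. Compound 3 `Cc1noc(C)c1NC(=O)N1CCC(c2nc(-c3ccc4ccccc4n3)no2)CC1` is not yet measured. It differs from compound 2 in one place: a group of 7 heavy atoms (5 carbon, 1 nitrogen, 1 oxygen; one five-membered aromatic ring with 2 hetero atoms) in place of a group of 7 heavy atoms (5 carbon, 1 oxygen, 1 sulfur; one six-membered non-aromatic ring with 1 hetero atom), on an amide-type nitrogen. For the measured compounds named here, only one measured step bears on this position, the one a 1.2-fold higher number from compound 1 to compound 2 (0.08 log units; within the scatter), in which the group on the same amide-type nitrogen was replaced by the group that now leaves, and the number hardly moved. That one step is the whole of the evidence, and it suggests that this amide-type nitrogen tolerates quite different groups without a change beyond the scatter. On that basis the step of a 1.3-fold lower number from compound 2 to compound 3 (0.12 log units; within the scatter) is expected to be small, with no direction that can be trusted. The estimate for compound 3 in this assay is 650 nM, expected to fall between 250 nM and 1800 nM.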

Compound 3, half-maximal inhibitory concentration: 3000 nM
The estimate for compound 3 lay 4.6-fold (0.66 log units) below the measured number; the whole stated range lies below it.
By their numbers in this assay, from the lowest: compounds 1 and 2 (each within the scatter of the next); then compound 3.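

The result shows that this amide-type nitrogen does not accept every group equally: with 3,5-dimethyl-1,2-oxazol-4-yl on it, this assay gives a 3.5-fold higher number from compound 2 to compound 3 (0.55 log units; beyond the scatter) and a 4.3-fold higher number from compound 1 to compound 3 (0.63 log units; beyond the scatter). The tolerance suggested by compounds 1 and 2, whose values lie within the scatter of each other despite their very different groups, therefore does not extend to compound 3, which goes against it. The group that enters and the group that leaves in the step to compound 3 have the same count of heavy atoms, so that count does not separate them, and nothing measured here gives a reason for the weaker inhibition.

Compound 3 is the only compound shown with a five-membered aromatic ring on this nitrogen, so the compounds cannot separate the part played by the ring itself from that of its two methyl groups or its ring nitrogen and oxygen. Going by these compounds, how an unsubstituted 1,2-oxazol-4-yl, a plain phenyl or an ethyl chain on this nitrogen would read in this assay also remains open.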